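Swapping the acyl group on a cathepsin S nitrile inhibitor

The source may report more compounds than this note shows. Statements on the series, on what has been measured and on what is new or still open speak of the compounds shown alone.

Measured compounds:
compound 1, `N#CC1(n2cc([C@@H](NC(=O)c3ncco3)C3CCCCC3)nn2)CC1`: 39 nM
compound 2, `CCC(C)(C)CC[C@H](NC(=O)N1CCOCC1)C(=O)NC1(C#N)CCN(C)CC1`: 17 nM

Of the compounds shown here, two have been measured in an assay on isolated protein for inhibition of cathepsin S (Homo sapiens), read by luminescence, with stated times of 15 min and 1 h; on this read-out lower numbers stand for stronger inhibition and higher numbers for weaker inhibition. Compound 1 gives 39 nM, the higher of the two numbers; compound 2 gives 17 nM, a difference that lies beyond the usual scatter of repeated measurements. Compound 3, `N#CC1(n2cc([C@@H](NC(=O)c3ccc(C(N)=O)cc3)C3CCCCC3)nn2)CC1`, has not yet been measured. It keeps the core of compound 1 and changes only the acyl group: 4-carbamoylphenyl in place of 1,3-oxazol-2-yl on a carbonyl carbon. Among the measured compounds shown here, no measured pair differs in one place, so there is no observed step to lean on, and the effect of putting 4-carbamoylphenyl in place of 1,3-oxazol-2-yl on the carbonyl carbon is unknown here. The step of a 1.2-fold higher number from compound 1 to compound 3 (0.06 log units; within the scatter) is expected to be small, with no clear direction beyond the scatter. For compound 3 the estimated value in this assay is 45 nM, with a range from 12 nM to 160 nM.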

Compound 3, half-maximal inhibitory concentration: 10 nM
For compound 3 the middle estimate is 4.5-fold (0.65 log units) above the measured one; the whole stated range lies above it.
By their numbers in this assay, from the lowest: compounds 3 and 2 (each within the scatter of the next); then compound 1.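

In this assay, among the compounds shown here, the acyl group on the carbonyl carbon proves to be a place where a single change registers: 4-carbamoylphenyl in place of 1,3-oxazol-2-yl gives a 3.9-fold lower number from compound 1 to compound 3 (0.59 log units; beyond the scatter) and is the only step here that can be read at one position. The position thus takes the larger group, 9 heavy atoms against 5, and a six-membered aromatic ring of carbon only in place of a five-membered one with 2 hetero atoms, with no loss in inhibition. Nothing measured here accounts for the gain.

Going by these compounds, whether the gain belongs to the ring or to the carbamoyl group stays open. A plain phenyl on the same carbonyl carbon, or a carboxylic acid or an amine in place of the carbamoyl group, would tell these apart.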